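Pyridin-3-yl Replaces 3,5-Dimethyl-1,2-oxazol-4-yl: Cytotoxicity Outlook

The compounds below may be only part of what the source reports. "The series", "measured", "known", "first", "only" and "open" are said of these compounds alone.

Compound 1 `Cc1noc(C)c1C(c1ccccc1)N1CCN(c2ncnc3c2cnn3-c2ccccc2)CC1` was tested in a functional assay on cells (Rhabdomyosarcoma cell, Homo sapiens) for cytotoxicity (on this read-out lower numbers stand for stronger inhibition and higher numbers for weaker inhibition), and gives > 25000 nM, which is a limit of the assay rather than a number. Compound 2 `Cc1ccsc1C(c1ccccc1Br)N1CCN(c2ncnc3c2cnn3-c2ccccc2)CC1` gives > 25000 nM, also a limit. Compound 3 `c1ccc(C(c2ccncc2)N2CCN(c3ncnc4c3cnn4-c3ccccc3)CC2)cc1` gives > 25000 nM, again a limit. The step that the two limits leave unreadable from compound 1 to compound 3 therefore cannot be sized, and the limit of > 25000 nM in this assay, at which 3 of the 3 values shown sit, sums up the whole measured set. Compound 4 `c1ccc(C(c2cccnc2)N2CCN(c3ncnc4c3cnn4-c3ccccc3)CC2)cc1` differs from compound 1 by pyridin-3-yl in place of 3,5-dimethyl-1,2-oxazol-4-yl on a saturated chain carbon bound to an amine nitrogen in a ring and an aromatic carbon. Going by the values given here, the only comparable step, from an oxazole to a pyridine, stays unreadable, so no shift beyond the scatter can be expected in this assay. Compound 4 is therefore estimated at 30000 nM, between 12000 nM and 80000 nM, meaning an expected step that the limit leaves unreadable from compound 1 to compound 4.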

Compound 4, half-maximal inhibitory concentration: > 25000 nM
Compound 4: only a limit was reported (the forecaster's own chance of this, stated with the estimate: 85%); the middle value does not contradict the limit.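

Compound 4, like compound 1 and compound 3, gives only a limit, so neither step to compound 4 can be read: the limit of > 25000 nM in this assay, at which 4 of the 4 values shown sit. The compounds shown leave open which structural change, if any, would give a measurable value in this assay.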